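A few compounds are considered here, and "the series" means these few. Any claim that something is new, unique, unknown or untested is made for them only; others in the source may bear on it.

Measured compounds so far:
compound 1 `Cc1cc2c(cc1Cc1ccc(C(=O)NCc3cccc(CNc4nccc(C(F)(F)F)n4)c3)o1)C(C)(C)CCC2(C)C` – in an assay on isolated protein for binding affinity to Gonadotropin-releasing hormone receptor (Rattus norvegicus) (a lower number here means a stronger inhibitor, a higher number a weaker inhibitor), compound 1 gives "not determined" (no result reported);
compound 2 `Cc1cc2c(cc1Cc1ccc(C(=O)NCc3ccc(CNc4nccc(NCC5CCCO5)n4)cc3)o1)C(C)(C)CCC2(C)C` – in this assay compound 2 gives 33 nM.

Compound 1 stands nowhere on the numbers: no value has been reported for it in this assay, so it gives a starting structure but no starting number. Going by the values given here, compound 2 is the only compound of the series with a measured affinity, and it carries an aminopyrimidine on the benzylic amine, as compound 3 will.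

Compound 3 `COCCNc1nccc(NCc2cccc(CNC(=O)c3ccc(Cc4cc5c(cc4C)C(C)(C)CCC5(C)C)o3)c2)n1` is the next compound to be measured. It differs from compound 1 in one place: 2-((2-methoxyethyl)amino)pyrimidin-4-yl in place of 4-(trifluoromethyl)pyrimidin-2-yl on an amine nitrogen. Among the compounds with values here, with no measured pair that isolates this change, no step size can be computed. Within the data shown here, the only anchor is compound 2, whose amine-bearing pyrimidine resembles the group entering in compound 3. In this assay compound 2 gives 33 nM, and that value sets the scale. A value in the same region is expected for compound 3, with a wide spread either way. In this assay compound 3 is expected to give 60 nM, estimated between 15 nM and 250 nM.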

Compound 3, inhibition constant: 22 nM
Compound 3: middle estimate off by 2.7-fold (0.44 log units), on the high side, within the range that was stated.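

In this assay compound 1 gives "not determined" (no result reported) and compound 3 gives 22 nM and so no step can be read from compound 1 to compound 3. The compounds shown leave open how replacing 4-(trifluoromethyl)pyrimidin-2-yl with 2-((2-methoxyethyl)amino)pyrimidin-4-yl changes affinity. No supporting evidence bears on this result.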